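Cytotoxicity notes on a fluorophenyl-swap series

The compounds below may be only part of what the source reports. "The series", "measured", "known", "first", "only" and "open" are said of these compounds alone.

Measured compounds:
compound 1 `COc1cc(/C=C2\CN(C)C/C(=C\c3ccccc3F)C2=O)cc(OC)c1`, 1240 nM
compound 2 `CN1C/C(=C\c2ccc(C#N)cc2)C(=O)/C(=C/c2ccccc2F)C1`, 590 nM
compound 3 `COc1cc(/C=C2\CN(C)C/C(=C\c3ccc(F)cc3)C2=O)cc(OC)c1`, 6140 nM

All three were run in a functional assay on HepG2 cells (Homo sapiens) for cytotoxicity, read by MTT assay, with a stated time of 24 h; a lower number here means a stronger inhibitor, a higher number a weaker inhibitor. Compound 2 gives the lowest of the three numbers, with compound 1 nearest and compound 3 furthest, both steps beyond the scatter. Compound 1 and compound 2 differ in more than one place, so the difference between the two cores is not broken down here.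

Compound 1 and compound 3 share a core and differ in one place only, (4-fluorophenyl in place of 2-fluorophenyl on a double-bonded chain carbon bound to a double-bonded ring carbon). That change gave a 5.0-fold higher number from compound 1 to compound 3 (0.69 log units; beyond the scatter), a modest weakening.

Compound 4 `CN1C/C(=C\c2ccc(F)cc2)C(=O)/C(=C/c2ccc(C#N)cc2)C1` has not yet been tested. It stands to compound 2 exactly as compound 3 stands to compound 1, with the same change at the same place: 4-fluorophenyl in place of 2-fluorophenyl on a double-bonded chain carbon bound to a double-bonded ring carbon. Resting on the one measured precedent, the step from compound 2 to compound 4 is expected to be of similar size and direction, a 4.9-fold higher number from compound 2 to compound 4 (0.69 log units; beyond the scatter), because compound 1 moved by a 5.0-fold higher number from compound 1 to compound 3 (0.69 log units; beyond the scatter). With one precedent only, the range is kept wide. Compound 4 is therefore estimated at 2900 nM, between 1000 nM and 8500 nM in this assay.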

Compound 4, half-maximal inhibitory concentration: 6140 nM
Compound 4: the middle estimate sits 2.1-fold (0.33 log units) below what was measured, and the stated range covers the measured number.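

In this assay, 4-fluorophenyl in place of 2-fluorophenyl on a double-bonded chain carbon bound to a double-bonded ring carbon again gives a higher number (a 10-fold higher number from compound 2 to compound 4 (1.02 log units; beyond the scatter)), so the direction seen on the core of compound 1 also appears on the core of compound 2. This rests on two matched pairs only: it does not establish a rule for the whole series, and it does not show why the number rises on either core. Set side by side, the two steps show no difference in size that can be told from scatter, so the change carried over between these two cores in both direction and size: the same change on two cores in this assay, a 5.0-fold higher number (0.69 log units; beyond the scatter) from compound 1 to compound 3 and a 10-fold higher number (1.02 log units; beyond the scatter) from compound 2 to compound 4, 2.1-fold (0.32 log units) apart, within the scatter of two such steps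

The compounds shown leave open what a chlorophenyl, a plain phenyl or a pyridyl ring would give at the same place on either core. They also leave open whether the step holds on a core carrying an amine or a carboxylic acid, and whether it appears in cell lines other than HepG2.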